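Compound 3: a carbamoylphenyl ring replaces the cyano-fluoro ring

A few compounds are considered here, and "the series" means these few. Any claim that something is new, unique, unknown or untested is made for them only; others in the source may bear on it.

In an ADME assay on L6 cells (Rattus norvegicus) for cytotoxicity, read by resazurin assay, with a stated time of 72 h (a higher number here means a weaker inhibitor, a lower number a stronger inhibitor), compound 1 `N#Cc1ccc(C(O)(c2ccc(C(F)(F)F)cc2)c2cccnc2)cc1` gives 76500 nM, and compound 2 `N#Cc1ccc(C(O)(c2ccc(C(F)(F)F)cc2)c2cccnc2)c(F)c1` gives 56100 nM. Among the measured compounds shown here, the only measured step between them is a 1.4-fold lower number from compound 1 to compound 2 (0.13 log units; within the scatter), which comes from fluoro in place of hydrogen on an aromatic carbon. Compound 2 therefore stands level with compound 1 on these numbers.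

Compound 3 `NC(=O)c1cccc(C(O)(c2ccc(C(F)(F)F)cc2)c2cccnc2)c1` differs from compound 2 more widely: 3-carbamoylphenyl in place of 4-cyano-2-fluorophenyl on a saturated chain carbon bound to two aromatic carbons and an oxygen on a saturated carbon. Put simply, this is 3-carbamoylphenyl in place of 4-cyano-2-fluorophenyl on a saturated chain carbon bound to two aromatic carbons and an oxygen on a saturated carbon.

Compound 3 has no fluoro, so the fluoro step bears on part of this change, and that step stayed within the scatter. For the measured compounds named here, no measured compound carries a carbamoyl group, so the other part has no guide in the data. With so little evidence, no step beyond the scatter is expected in this assay, in either direction, and the range must stay wide.

The estimated change is a 1.2-fold higher number from compound 2 to compound 3 (0.10 log units; within the scatter). Compound 3 is expected at about 70000 nM, with an estimated range of 30000 nM to 160000 nM.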

Compound 3, half-maximal inhibitory concentration: > 100000 nM
Compound 3: only a limit was reported; the forecaster's own chance of this, stated with the estimate: 20%; middle value at least 1.4-fold (0.15 log units) from the limit.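

In this assay, compound 3 is reported only as a limit, not as a number: the limit of > 100000 nM in this assay, at which 1 of the 3 values shown sits.

Even so, the limit sets a floor on each new step: the change to 3-carbamoylphenyl gives an at least 1.7-fold higher number from compound 2 to compound 3 (0.25 log units; that floor lies within the scatter), and the same ring gives an at least 1.3-fold higher number from compound 1 to compound 3 (0.11 log units; that floor lies within the scatter). The earlier compounds shown here showed only that adding a fluoro to the ring on this carbon made no step beyond the scatter, whereas this result shows that the whole ring can be exchanged, with a nitrile giving way to a carbamoyl group and a hydrogen-bond donor entering, without a lower number in this assay.

From the compounds shown here alone, since both floors lie within the scatter, the true size of these steps remains unknown, and any step could be small or large. The change also alters both the group and the numbered ring position it occupies, so 3-cyanophenyl and 4-carbamoylphenyl would be needed to separate the two, while 3-carboxyphenyl or 3-aminophenyl would show how other groups behave on this ring.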